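The source may report more compounds than this note shows. Statements on the series, on what has been measured and on what is new or still open speak of the compounds shown alone.

Measured compounds:
Compound 1 `Cc1c(C(=O)N/N=C\c2ccc(O)cc2)oc2cccc(O)c12`; in a functional assay on PC-3 cells (Homo sapiens) for inhibition (on this read-out higher numbers stand for weaker inhibition and lower numbers for stronger inhibition), compound 1 gives 21700 nM.
Compound 2 `Cc1c(C(=O)N/N=C\c2cccc(O)c2)oc2cccc(O)c12`; in this assay compound 2 gives 17600 nM.

Compound 2 carries the lower of the two numbers, but a 1.2-fold lower number from compound 1 to compound 2 (0.09 log units; within the scatter), so the two compounds are not separated by the assay. Compound 3 `Cc1c(C(=O)N/N=C\c2cccnc2)oc2cccc(O)c12` differs from compound 2 by pyridin-3-yl in place of 3-hydroxyphenyl on a carbon with a double bond to nitrogen. Within the data shown here, only one measured step exists, and it moves the hydroxyl group around the ring rather than removing it; it does not show what happens when the ring loses its hydrogen-bond donor and gains a ring nitrogen. Among the measured compounds shown here, that step was small, and the series so far gives no sign that changes on this ring move the number far. For the measured compounds named here, on that basis the step of a 1.4-fold higher number from compound 2 to compound 3 (0.15 log units; within the scatter) is expected to be small, with a slight drift towards a higher number allowed for because the one comparison, a 1.2-fold lower number from compound 1 to compound 2 (0.09 log units; within the scatter), left the number essentially unchanged. Compound 3 is therefore estimated at 25000 nM in this assay, within a range from 8000 nM to 80000 nM.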

Compound 3, half-maximal inhibitory concentration: >= 40000 nM
Compound 3 ended at the assay's limit (the forecaster's own chance of this, stated with the estimate: 15%); at least 1.6-fold (0.20 log units) between middle value and limit.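

In this assay, among these compounds, placing pyridin-3-yl on the carbon with a double bond to nitrogen gives an at least 2.2-fold higher number from compound 2 to compound 3 (0.35 log units; beyond the scatter); this is the only step among the three compounds printed as beyond the scatter, so this position is not as indifferent to change as moving the hydroxyl group suggested. Measured against the 4-hydroxyphenyl group, the same ring gives an at least 1.8-fold higher number from compound 1 to compound 3 (0.26 log units; that floor lies within the scatter), and this comparison alone therefore does not separate the two compounds. On these data alone, the value of compound 3 is a limit of the assay and not a number, so both steps give only a floor and their full size remains unknown: the limit of >= 40000 nM in this assay, at which 1 of the 3 values shown sits.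

The compounds shown leave open whether the loss of the hydroxyl group or the entry of the ring nitrogen matters more, as the two changes arrive together in compound 3. Also open, as far as these compounds go, is how a plain phenyl ring, or a phenyl ring carrying an amine or a carboxylic acid in place of the hydroxyl group, would read in this assay.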